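From phenyl to 3-chlorophenyl in compound 2

This account rests on a few compounds, and the source may have more. Where it says the series, first, only, none or still open, it means among the compounds named here.

In a functional assay on HL-60 cells (Homo sapiens) for inhibition, read by MTT assay, with a stated time of 72 h (on this read-out higher numbers stand for weaker inhibition and lower numbers for stronger inhibition), compound 2 (`Cc1ccc(C)c(N2CCN(C(=O)c3oc(C)nc3-c3ccccc3)CC2)c1`) gives 31.3 nM. Within the data shown here, compound 1 (`Cc1nc(-c2ccccc2)c(C(=O)N2CCN(c3cccc(C)c3C)CC2)o1`) gives 35 nM, and these are the only two numbers available. They stand level, since exchanging the 2,3-dimethylphenyl group on the amine nitrogen for 2,5-dimethylphenyl amounts to a 1.1-fold lower number from compound 1 to compound 2 (0.05 log units; within the scatter). Compound 3 (`CC(=O)c1ccc(N2CCN(C(=O)c3oc(C)nc3-c3ccccc3)CC2)cc1`), with another group on that nitrogen, is recorded as "not active" (no number reported), without a number.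

Compound 4 (`Cc1ccc(C)c(N2CCN(C(=O)c3oc(C)nc3-c3cccc(Cl)c3)CC2)c1`) keeps the 2,5-dimethylphenyl group of compound 2 and changes phenyl to 3-chlorophenyl, with chloro in place of hydrogen on an aromatic carbon, meta to a large group: chloro in place of hydrogen on an aromatic carbon. Among the measured compounds shown here, no measured step touches this phenyl. For the measured compounds named here, the one available step, a 1.1-fold lower number from compound 1 to compound 2 (0.05 log units; within the scatter), lies elsewhere in the molecule and gives no size for this change. Compound 3 does show that a compound of this set can go without a number, so some risk remains. With no evidence for a direction, no step beyond the scatter is expected, and the starting point stays compound 2 at 31.3 nM, with a wide margin on either side. The expected change is a 1.0-fold lower number from compound 2 to compound 4 (0.02 log units; within the scatter). For compound 4 the estimated value is 30 nM, within an expected range from 9 nM to 110 nM.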

Compound 4, half-maximal inhibitory concentration: 345 nM
Estimate against measurement, compound 4: 12-fold (1.06 log units) below; measured number outside the range, above it.
By their numbers in this assay, from the lowest: compounds 2 and 1 (each within the scatter of the next); then compound 4.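

In this assay, the phenyl group proves sensitive to change: chloro in place of hydrogen on an aromatic carbon, meta to a large group, brings an 11-fold higher number from compound 2 to compound 4 (1.04 log units; beyond the scatter). Among these compounds, the only earlier step, a 1.1-fold lower number from compound 1 to compound 2 (0.05 log units; within the scatter), changed the dimethylphenyl group on the amine nitrogen and stayed within the scatter, so it gave no sign that a single-site change in this set could move the number this far. Here the entering group is one chlorine atom, and that alone takes the pair beyond the scatter towards weaker inhibition, although no measurement shown explains why this happens.

Going by these compounds, what stays open is whether this step belongs to chloro in particular or would come with other groups at this place, such as fluoro, methyl, methoxy or an amine, and whether a chloro elsewhere on the phenyl ring would act in the same way. On these data alone, it is also open whether the same change would give a step of similar size with the 2,3-dimethylphenyl group of compound 1, since the step is known from one pair only.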